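Chain length and 12-lipoxygenase inhibition by acetylenic aryl propanoic acids

The source may report more compounds than this note shows. Statements on the series, on what has been measured and on what is new or still open speak of the compounds shown alone.

Compound 1 `CCCCCCCCC#CCOCc1cccc(CCC(=O)O)c1`: 10000 nM
Compound 2 `CCCCCCCCCCC#CCOCc1cccc(CCC(=O)O)c1`: 320 nM
Compound 3 `CCCCCCCCCCCCC#CCOCc1ccc(CCC(=O)O)cc1`: 320 nM

In an assay on isolated protein for inhibition of Arachidonate 12-lipoxygenase (Sus scrofa) (a higher number here means a weaker inhibitor, a lower number a stronger inhibitor), compound 1 gives 10000 nM, while compound 2 gives 320 nM. The change between them, (ethyl in place of hydrogen on a saturated chain carbon, eight bonds along the chain from a triple-bonded carbon), brought a 31-fold lower number from compound 1 to compound 2 (1.49 log units; beyond the scatter). Compound 3 is built on a different core; the difference between the two cores is not broken down here. In this assay compound 3 gives 320 nM, level with compound 2 at the digits shown.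

Compound 4 `CCCCCCCCCCCCCCC#CCOCc1ccc(CCC(=O)O)cc1` has not been measured. It differs from compound 3 by ethyl in place of hydrogen on a saturated chain carbon, ten or more bonds along the chain from a triple-bonded carbon. For the measured compounds named here, this is the same kind of change as the one from compound 1 to compound 2, but the place of the added ethyl along the chain from a triple-bonded carbon is not identical, as the two differences themselves describe. Because compound 3 already gives 320 nM, the same value as compound 2, the large gain seen in a 31-fold lower number from compound 1 to compound 2 (1.49 log units; beyond the scatter) is not expected to repeat in full; a smaller step, a 1.6-fold lower number from compound 3 to compound 4 (0.20 log units; within the scatter), is expected. Compound 4 is therefore estimated at 200 nM, with a likely range from 60 nM to 800 nM.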

Compound 4, half-maximal inhibitory concentration: > 10000 nM
Compound 4: a limit, no number; the forecaster's own chance of this, stated with the estimate: 5%; middle value at least 50-fold (1.69 log units) away from the limit.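

In this assay, the ethyl in place of hydrogen on a saturated chain carbon did not carry over from one core to the other: where it had given a 31-fold lower number from compound 1 to compound 2 (1.49 log units; beyond the scatter), the new step is an at least 31-fold higher number from compound 3 to compound 4 (1.49 log units; beyond the scatter), and the two steps run in opposite directions: the same change on two cores in this assay, a 31-fold lower number (1.49 log units; beyond the scatter) from compound 1 to compound 2 and an at least 31-fold higher number (1.49 log units; beyond the scatter) from compound 3 to compound 4, at least 970-fold (2.98 log units) apart, beyond the scatter of two such steps

Compound 4 gives > 10000 nM, which is a limit of the assay and not a number, so the size of the new step has only a bound.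

The pair does not show whether the core or the place of the ethyl along the chain decides the direction, since the core and that place both differ between the two steps.

The compounds shown leave open how the chain of compound 3 or compound 4 would behave on the core of compound 1, which would separate the core from the chain. They also leave open whether a longer chain stays at the limit, and whether an amide in place of the carboxylic acid would alter this pattern.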